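Sec-butyl in Place of Pentan-3-yl on the Nitrogen

The compounds below may be only part of what the source reports. "The series", "measured", "known", "first", "only" and "open" are said of these compounds alone.

Two measured compounds share one core. Compound 1 `CC(C)(C)/N=c1\c(O)c(O)\c1=N/Cc1ccc(F)cc1F` gives 2100 nM in a functional assay for inhibition, with Rattus norvegicus as the target; a lower number here means a stronger inhibitor, a higher number a weaker inhibitor. Compound 2 `CCC(CC)/N=c1\c(O)c(O)\c1=N/Cc1ccc(C#N)cc1` gives 1300 nM in this assay, the lowest of the two numbers, yet its gap to compound 1 lies within the scatter, so neither compound can be called the stronger one. Compound 3 `CC[C@H](C)/N=c1\c(O)c(O)\c1=N/Cc1ccc(C#N)cc1` differs from compound 2 in one place: sec-butyl in place of pentan-3-yl on a double-bonded nitrogen. Among the compounds with values here, no measured pair shows such a change, so only a small step is expected, in either direction, probably not beyond the scatter. Compound 3 is therefore estimated at 1500 nM, between 600 nM and 4000 nM. The step this estimate implies is a 1.2-fold higher number from compound 2 to compound 3 (0.06 log units; within the scatter).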

Compound 3, half-maximal inhibitory concentration: 2200 nM
Beside the measured number, compound 3's estimate is 1.5-fold (0.17 log units) below it; low and high end bracket the measured number.
By their numbers in this assay, from the lowest: compounds 2, 1 and 3 (each within the scatter of the next).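

In this assay, within the data shown here, the swap of pentan-3-yl for sec-butyl on the double-bonded nitrogen gives a 1.7-fold higher number from compound 2 to compound 3 (0.23 log units; within the scatter) and so offers the first direct look at this position. Within this single pair, the change of chain leaves no difference that can be told from the scatter. As far as these compounds go, it remains open whether a ring such as cyclopentyl, a longer chain such as hexyl, or a chain carrying an amine would shift the number, and what the mirror-image form of sec-butyl would give. No measurement shown here bears on the reason for this result.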